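The source may report more compounds than this note shows. Statements on the series, on what has been measured and on what is new or still open speak of the compounds shown alone.

Working notes on the nitroimidazole-oxazine series, cytotoxicity arm.

Compound 1 `O=[N+]([O-])c1cn2c(n1)OC(COc1cccc(-c3ccc(F)cc3F)n1)CC2` is the parent of the first pair. In an ADME assay on MRC5 cells (Homo sapiens) for cytotoxicity, read by resazurin assay, with a stated time of 72 h (a higher number here means a weaker inhibitor, a lower number a stronger inhibitor), compound 1 gives only a limit, > 64000 nM. Compound 2 `CC1(COc2cccc(-c3ccc(F)cc3F)n2)CCn2cc([N+](=O)[O-])nc2O1` carries methyl in place of hydrogen on a saturated ring carbon. In this assay compound 2 likewise gives only a limit, > 64000 nM. The step that the two limits leave unreadable from compound 1 to compound 2 therefore cannot be sized.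

Compound 3 `O=[N+]([O-])c1cn2c(n1)OC(COc1ccc(-c3ccc(OC(F)(F)F)cc3)cn1)CC2` has a different core; the difference between the cores of compound 1 and compound 3 is not broken down here. In this assay compound 3 gives only a limit, > 64000 nM. Within the data shown here, all values so far sit at the limit of > 64000 nM in this assay, at which 3 of the 3 values shown sit.

Compound 4 `CC1(COc2ccc(-c3ccc(OC(F)(F)F)cc3)cn2)CCn2cc([N+](=O)[O-])nc2O1` carries the same change as the first pair, (methyl in place of hydrogen on a saturated ring carbon). Since the step from compound 1 to compound 2 stayed unreadable at the limit, compound 4 is expected to stay at the limit as well, with an expected step that the limit leaves unreadable from compound 3 to compound 4. For compound 4 the estimate is 100000 nM, expected between 40000 nM and 300000 nM, pending measurement.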

Compound 4, half-maximal inhibitory concentration: > 64000 nM
Compound 4: only a limit was reported (the forecaster's own chance of this, stated with the estimate: 85%); the middle value lies beyond the limit too.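

Compound 3 and compound 4 each give only a limit in this assay, so no step between them can be read: the limit of > 64000 nM in this assay, at which 4 of the 4 values shown sit.

The compounds shown leave open whether methyl in place of hydrogen on a saturated ring carbon changes the read-out in this assay at all.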